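Swapping Chloro for Bromo and the Cytotoxicity Ceiling

The compounds below may be only part of what the source reports. "The series", "measured", "known", "first", "only" and "open" are said of these compounds alone.

Compound 1, `COc1ccc2nc(C)cc(OCC(=O)Nc3ccc(Br)cc3)c2c1`, gives in an ADME assay on HepG2 cells (Homo sapiens) for cytotoxicity, read by trypan blue exclusion, with a stated time of 48 h, in the presence of a further agent that is not named here (a higher number here means that more compound is tolerated, a lower number that less compound is tolerated), only a limit, > 125000 nM.
Compound 2, `COc1ccc2nc(C)cc(OCC(=O)Nc3ccc(Cl)cc3)c2c1`, gives in this assay 71100 nM.
Compound 3, `COc1ccccc1NC(=O)COc1cc(C)nc2ccc(Cl)cc12`, gives in this assay 99200 nM.

Compounds 2 and 1 differ by bromo in place of chloro on an aromatic carbon, and this change made the step of an at least 1.7-fold higher number from compound 2 to compound 1 (0.24 log units; that floor lies within the scatter). That step is only a floor because of the limit of > 125000 nM in this assay, at which 1 of the 3 values shown sits. Compounds 3 and 2 are built from the same atoms joined differently; the difference between the two cores is not broken down here, and their two numbers lie within the scatter of each other.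

Compound 4, `COc1ccccc1NC(=O)COc1cc(C)nc2ccc(Br)cc12`, remains to be measured. It differs from compound 3 by bromo in place of chloro on an aromatic carbon. This is the same kind of change as that from compound 2 to compound 1, though the surroundings differ: there the ring was not part of a fused system and the site sat para to a large group, whereas here the ring is part of a fused or bridged system of two rings and the site is meta and para to a fused ring. Going from compound 3 to compound 4, a step of a 1.3-fold higher number from compound 3 to compound 4 (0.12 log units; within the scatter) is expected, resting on the floor seen in an at least 1.7-fold higher number from compound 2 to compound 1 (0.24 log units; that floor lies within the scatter). Compound 4 is estimated at 130000 nM, between 70000 nM and 250000 nM, with a fair chance that only a limit is reported.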

Compound 4, half-maximal cytotoxic concentration: > 125000 nM
Compound 4 ended at the assay's limit; the forecaster's own chance of this, stated with the estimate: 55%; the middle value lies beyond the limit too.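

Swapping chloro for bromo on the second core gives an at least 1.2-fold higher number from compound 3 to compound 4 (0.10 log units; that floor lies within the scatter), so here, as on the first core, the change yields only a floor and not a measured size. Set side by side, the two steps read: the same change on two cores in this assay, an at least 1.7-fold higher number (0.24 log units; that floor lies within the scatter) from compound 2 to compound 1 and an at least 1.2-fold higher number (0.10 log units; that floor lies within the scatter) from compound 3 to compound 4; the limit leaves it open whether they differ. The change carries over to the second core with no sign of a drop in the concentration tolerated, but this does not show that bromo truly raises that concentration on either core, or that it acts equally on both, because the true values of the bromo compounds stay out of reach: the limit of > 125000 nM in this assay, at which 2 of the 4 values shown sit.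

The compounds shown leave open how much compound 1 and compound 4 would tolerate past that limit, and so how large the change really is. They also leave open what other groups on the same aromatic carbon, such as fluoro, methyl or an amine, would give on either core.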